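The source may hold more compounds than are shown below. What is called first, only, known or untested is meant among the compounds shown, and "the series" means these compounds.

Compound 1: `Cc1nn(-c2ccccn2)c2cc(-c3cccc(CCC(=O)O)c3)ccc12`, 0%
Compound 2: `Cc1nn(-c2ccccn2)c2cc(-c3ccc(CCC(=O)O)cc3)ncc12`, 86%
Compound 3: `COc1cc(CCC(=O)O)ccc1-c1ccc2c(C)nn(-c3ccccn3)c2c1`, 62%

Of the compounds shown here, three sharing one core have been tested in a functional assay on cells for agonist activity at Free fatty acid receptor 1 (Mus musculus), read by FLIPR and calcium flux, with a stated time of 5 min; on this read-out higher numbers stand for larger maximal responses and lower numbers for smaller maximal responses. Compound 1 gives 0%, the lowest of the three. Compound 2 gives 86%, the highest. Compound 3 stands second with 62%: compound 2 sits beyond the usual scatter above it, and compound 1 sits far beyond the scatter below it.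

Compound 4, `Cc1nn(-c2ccccn2)c2cc(-c3ccc(CCC(=O)O)cc3Cl)ccc12`, has not yet been measured in this assay. It differs from compound 3 in one place: chloro in place of methoxy on an aromatic carbon. A methoxy leaves and a chloro enters, ortho to a large group and meta to the 2-carboxyethyl group. Among the compounds with values here, no pair of measured compounds differs by such a change, so nothing measured shows how large a step it brings. Since the rest of the structure is unchanged, the step of a number 3 percentage points higher from compound 3 to compound 4 (within the scatter) is expected to be small, within the scatter. Compound 4 is therefore expected to give about 65%, with a range from 40% to 90%.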

Compound 4, largest response reached (reported as efficacy), in percent of the reference or control that the assay uses: 102%
For compound 4 the middle estimate is 37 percentage points below the measured one; measured number outside the range, above it.
By their numbers in this assay, from the lowest: compound 1; then compound 3; then compound 2; then compound 4.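

This aromatic carbon, ortho to a large group and meta to the 2-carboxyethyl group, turns out to matter for the maximal response. In this assay, chloro in place of methoxy gives a number 40 percentage points higher from compound 3 to compound 4 (beyond the scatter) even though the rest of the structure stays the same. The earlier compounds shown here could not show this, since no two of them differed in one place, and this single exchange of one small group for another now shows that a change at this carbon can move the response well beyond normal variation. Nothing available explains why the step is so large.

Going by these compounds, how a plain hydrogen, a fluoro or a methyl at this carbon would compare with chloro and methoxy remains open. On these data alone, it is also open whether chloro would bring a similar step on the core of compound 2.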